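Bromo in place of methoxy at the assay limit

This account rests on a few compounds, and the source may have more. Where it says the series, first, only, none or still open, it means among the compounds named here.

Measured in a functional assay on Malme-3M cells (Homo sapiens) for cytotoxicity, read by MTT assay, with a stated time of 6 days; a higher number here means that more compound is needed for the effect, a lower number that less compound is needed:
- compound 1 `COC(=O)c1c(-c2cc(OC)cc(OC)c2)oc2ccccc2c1=O` gives > 25 ug/mL
- compound 2 `COC(=O)c1c(-c2ccc(OC)cc2)oc2ccccc2c1=O` gives > 25 ug/mL

Neither entry is a number; each is a limit of the assay. Compound 2 therefore has no exact position in this assay and shares (the limit of > 25 ug/mL in this assay, at which 2 of the 2 values shown sit). The next compound, compound 3 `COC(=O)c1c(-c2ccc(Br)cc2)oc2ccccc2c1=O`, carries bromo in place of methoxy on an aromatic carbon, para to a large group (bromo in place of methoxy on an aromatic carbon). Among the measured compounds shown here, no measured step is available to size this change. In this assay, a shift no larger than the usual scatter is expected, with no firm direction, and another limit is the likeliest report. The estimated step is a number no higher from compound 2 to compound 3 (the limit leaves the size open). For compound 3 the expected value is 25 ug/mL, with an estimated range from 10 ug/mL to 50 ug/mL.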

Compound 3, concentration for half-maximal effect: > 25 ug/mL
Compound 3 gave a limit, no number (the forecaster's own chance of this, stated with the estimate: 70%); the middle value lies on the limit itself.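

Compound 2 and compound 3 are both reported in this assay only as limits, so no step can be read for bromo in place of methoxy: the limit of > 25 ug/mL in this assay, at which 3 of the 3 values shown sit.

The compounds shown leave open how far any of them lies beyond that limit and whether this change alters the value at all.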